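Sulfoxide to sulfone on a triazole: an inactive series

This account rests on a few compounds, and the source may have more. Where it says the series, first, only, none or still open, it means among the compounds named here.

Compound 1 `Cn1c(-c2cccs2)nnc1[S+](C)[O-]`: > 200 mg/kg
Compound 2 `Cn1c(-c2cccs2)nnc1S(C)(=O)=O`: > 200 mg/kg
Compound 3 `Cn1c(-c2cccc3ccccc23)nnc1[S+](C)[O-]`: > 200 mg/kg

In a functional assay on the whole organism for antagonist activity, with Mus musculus as the target (on this read-out lower numbers stand for an effect already at smaller amounts and higher numbers for an effect only at larger amounts of compound), compound 1 reaches only a limit of the assay, > 200 mg/kg. Compound 2 likewise stops at a limit, > 200 mg/kg. The change between them is a group of 4 heavy atoms (1 carbon, 2 oxygen, 1 sulfur; no ring) in place of a group of 3 heavy atoms (1 carbon, 1 oxygen, 1 sulfur; no ring), on an aromatic carbon, and the step that the two limits leave unreadable from compound 1 to compound 2 cannot be sized because both values sit at the limit of > 200 mg/kg in this assay, at which 3 of the 3 values shown sit. Compound 3 also gives only a limit, > 200 mg/kg; how its core differs from that of compound 1 is not broken down here.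

Compound 4 `Cn1c(-c2cccc3ccccc23)nnc1S(C)(=O)=O` is not yet measured. It carries the same kind of change as compound 2 does, namely (a group of 4 heavy atoms (1 carbon, 2 oxygen, 1 sulfur; no ring) in place of a group of 3 heavy atoms (1 carbon, 1 oxygen, 1 sulfur; no ring), on an aromatic carbon); the surroundings differ only in the group that sits two ring bonds from it. Since compound 3 sits at the limit > 200 mg/kg, and compound 1 and compound 2 share the same limit, the step that the limit leaves unreadable from compound 3 to compound 4 is expected to be unreadable in the same way. Compound 4 is therefore estimated at about 400 mg/kg, most likely reported as a limit again.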

Compound 4, dose for half-maximal effect: > 200 mg/kg
Compound 4 was reported as a limit; the forecaster's own chance of this, stated with the estimate: 85%; the middle value lies beyond the limit too.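

Compound 3 and compound 4 both stop at a limit of the assay, so no step can be read for the change to methylsulfonyl, because neither gives an actual number: the limit of > 200 mg/kg in this assay, at which 4 of the 4 values shown sit.

The compounds shown leave open what dose, if any, gives a half-maximal effect, and whether the change to methylsulfonyl alters that dose at all.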